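The compounds below may be only part of what the source reports. "The series", "measured", "known", "first", "only" and "open" are said of these compounds alone.

Measured compounds:
compound 1 `CCOC(=O)CNC(=O)N1CC1C#N` gives 25000 nM in a functional assay on RPMI-8226 cells (Homo sapiens) for inhibition; a higher number here means a weaker inhibitor, a lower number a stronger inhibitor;
compound 2 `CCOC(=O)c1ccc(NC(=O)N2CC2C#N)cc1` gives 3000 nM in this assay.

Compound 2 stands at the lower of the two measured values in this assay, and the gap from it to compound 1 lies beyond the usual scatter of this kind of measurement. Compound 1 and compound 2 differ in more than one place, so their pair shows only that the aromatic urea partner of compound 2 goes with the lower number.

The next compound, compound 3 `N#CC1CN1C(=O)Nc1ccc(C(F)(F)F)cc1`, keeps the core of compound 2 and changes one group: trifluoromethyl in place of ethoxycarbonyl on an aromatic carbon. Among the measured compounds shown here, no measured pair shows this change, so its effect in this assay is not known from the data. Both groups sit on the same aromatic carbon and both are small, so a step of moderate size at most is expected, in either direction, and a result within the scatter of compound 2 would not surprise. Compound 3 is therefore expected to give about 2500 nM, with a range from 800 nM to 8000 nM, which corresponds to an expected step of a 1.2-fold lower number from compound 2 to compound 3 (0.08 log units; within the scatter).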

Compound 3, half-maximal inhibitory concentration: 8200 nM
Compound 3: the middle estimate sits 3.3-fold (0.52 log units) below what was measured, and the stated range ends below it.
By their numbers in this assay, from the lowest: compound 2; then compound 3; then compound 1.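

In this assay, trifluoromethyl in place of ethoxycarbonyl on an aromatic carbon, para to a group of 8 heavy atoms, gives a 2.7-fold higher number from compound 2 to compound 3 (0.44 log units; beyond the scatter), so this position is sensitive to the group it carries, and of these two groups ethoxycarbonyl goes with the lower number. The step is modest but lies beyond the scatter, and the change exchanges a group with 2 hydrogen-bond acceptors and a double bond for one with neither, while the heavy-atom count moves only from 5 to 4. Nothing shown here measures a property of either group or otherwise accounts for the step, so it stands as an observation about this one exchange.

The compounds shown leave open which part of ethoxycarbonyl goes with the lower number, a question that a carboxylic acid, a methyl ester or a primary amide at the same carbon would help to separate. They also leave open how a group of another kind, such as an amine, a methoxy group or a single chlorine atom, would behave there.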